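The compounds below may be only part of what the source reports. "The series", "measured", "known", "first", "only" and "open" are said of these compounds alone.

Series notes. The shared core is carried by compound 1 `Cn1c(Cc2nn(C)c(=O)c3ccccc23)nnc1SCCCCCCCC(=O)Nc1ccc(Cl)cc1Cl`, compound 2 `Cn1c(Cc2nn(C)c(=O)c3ccccc23)nnc1SCCCCCCCCCCC(=O)Nc1ccc(Cl)cc1Cl` and compound 3 `COc1ccc(NC(=O)CCCCCCCSc2nnc(Cc3nn(C)c(=O)c4ccccc34)n2C)cc1`, which differ in the chain and in the aryl group on the amide-type nitrogen. In an assay on isolated protein for binding affinity to interleukin-15 (Homo sapiens), read by surface plasmon resonance (a lower number here means tighter binding, a higher number weaker binding), compound 1 gives 19100 nM. In this assay compound 2 gives "not determined" (no result reported), so no number is available for it. In this assay, among the compounds with values here, compound 3 gives 26000 nM, the higher of the two numbers known, though the step of a 1.4-fold higher number from compound 1 to compound 3 (0.13 log units; within the scatter) is within the scatter, so no order between compound 1 and compound 3 can be read from it.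

Compound 4 `Cc1ccc(NC(=O)CCCCCCCSc2nnc(Cc3nn(C)c(=O)c4ccccc34)n2C)c(Cl)c1` is not yet measured. Its change from compound 3 is 2-chloro-4-methylphenyl in place of 4-methoxyphenyl on an amide-type nitrogen. Within the data shown here, the only step that bears on it is a 1.4-fold higher number from compound 1 to compound 3 (0.13 log units; within the scatter), an exchange of aryl groups at the same place that produced nothing beyond the scatter. Among the measured compounds shown here, no measured step shows a chlorine or a methyl on this aryl ring alone, so nothing further can be read. For compound 4 a step of a 1.2-fold lower number from compound 3 to compound 4 (0.09 log units; within the scatter) is expected, within the scatter. Compound 4 is therefore estimated at 21000 nM in this assay, with a range from 8000 nM to 55000 nM.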

Compound 4, dissociation constant: 24100 nM
Compound 4: the middle estimate sits 1.1-fold (0.06 log units) below what was measured, and the stated range covers the measured number.
By their numbers in this assay, from the lowest: compounds 1, 4 and 3 (each within the scatter of the next).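

In this assay, replacing 4-methoxyphenyl with 2-chloro-4-methylphenyl on the amide-type nitrogen gives a step within the scatter (a 1.1-fold lower number from compound 3 to compound 4 (0.03 log units; within the scatter)). Within the data shown here, the change of methyl in place of chloro on an aromatic carbon is the first single-substituent exchange on this aryl ring, and it also stays within the scatter (a 1.3-fold higher number from compound 1 to compound 4 (0.10 log units; within the scatter)), so the three aryl groups at this place cannot be ordered. No available data bear on the reason for this flat reading.

Still open, going by these compounds, is whether a ring carrying an amine or a carboxylic acid, or a benzyl group in place of the aryl ring, would move the number beyond the scatter. Among these compounds, also open is what a shorter or longer chain would do, as no step with numbers on both sides changes the chain.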